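This account rests on a few compounds, and the source may have more. Where it says the series, first, only, none or still open, it means among the compounds named here.

Among the measured compounds shown here, compound 2 `Cc1cc(C(=O)Nc2cccc(-c3oc4cc(-c5ccc(F)cc5)ccc4c(=O)c3O)c2)ccc1F` stands at 11500 nM in a functional assay on A549 cells (Homo sapiens) for antiproliferative activity, read by CCK-8 assay, with a stated time of 72 h (on this read-out lower numbers stand for stronger inhibition and higher numbers for weaker inhibition), where the only comparison is compound 1 `COc1ccc(C(=O)Nc2cccc(-c3oc4cc(-c5ccc(F)cc5)ccc4c(=O)c3O)c2)cc1` at 8700 nM; the step of a 1.3-fold higher number from compound 1 to compound 2 (0.12 log units; within the scatter) stays within the scatter. Compound 3 `O=C(Nc1cccc(-c2oc3cc(-c4ccc(F)cc4)ccc3c(=O)c2O)c1)c1ccc(-c2ccccc2)cc1` differs from compound 2 by 4-phenylphenyl in place of 4-fluoro-3-methylphenyl on a carbonyl carbon, a change at the same carbonyl carbon. For the measured compounds named here, the one measured step there, a 1.3-fold higher number from compound 1 to compound 2 (0.12 log units; within the scatter), was small, so no step beyond the scatter is expected for compound 3, a 1.2-fold lower number from compound 2 to compound 3 (0.06 log units; within the scatter). Compound 3 is accordingly estimated at 10000 nM in this assay, with a range of 3000 nM to 35000 nM.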

Compound 3, half-maximal inhibitory concentration: > 100000 nM
Compound 3: only a limit was reported; the forecaster's own chance of this, stated with the estimate: 10%; middle value at least 10-fold (1.00 log units) away from the limit.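

At this carbonyl carbon the aryl group is not interchangeable: with 4-phenylphenyl the read-out moves by an at least 8.6-fold higher number from compound 2 to compound 3 (0.93 log units; beyond the scatter), and by an at least 11-fold higher number from compound 1 to compound 3 (1.06 log units; beyond the scatter), whereas the two single-ring groups stayed within the scatter of each other. Compound 3 in this assay gives a limit, not a number: the limit of > 100000 nM in this assay, at which 1 of the 3 values shown sits. The size of these steps therefore has only a lower bound.

Open, as far as these compounds go, is how a phenyl carrying an amine or a carboxylic acid, or a plain alkyl chain, would read at this carbonyl carbon. Also open, from the compounds shown here alone, is whether any group here gives a number clearly lower than that of compound 1.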